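Chloro for Fluoro Where Cytotoxicity Sits at the Limit

The compounds below may be only part of what the source reports. "The series", "measured", "known", "first", "only" and "open" are said of these compounds alone.

compound 1 `O=C(O)c1cccc(-c2ccc(/C=C3\S/C(=N\c4ccccc4)N(c4ccc(Cl)cc4)C3=O)s2)c1`: > 200000 nM
compound 2 `O=C(O)c1cccc(-c2ccc(/C=C3\S/C(=N\c4ccccc4)N(c4ccc(F)cc4)C3=O)s2)c1`: > 200000 nM
compound 3 `O=C(O)c1cccc(-c2ccc(/C=C3\S/C(=N\c4ccc(F)cc4)N(c4ccccn4)C3=O)o2)c1`: > 200000 nM

The three compounds were examined in an ADME assay on Vero cells (Chlorocebus sabaeus) for cytotoxicity; a higher number here means that more compound is tolerated, a lower number that less compound is tolerated. In this assay compound 1 gives > 200000 nM, which is a limit of the assay and not a number. Compound 2 likewise gives > 200000 nM, again a limit. Compound 3 gives > 200000 nM, also a limit.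

Compound 1 and compound 2 share one core and differ by chloro in place of fluoro on an aromatic carbon. The resulting step that the two limits leave unreadable from compound 2 to compound 1 cannot be read because the limit of > 200000 nM in this assay, at which 3 of the 3 values shown sit, is where both values sit. Compound 3 carries a different core; how the two cores differ is not broken down here.

Compound 4 `O=C(O)c1cccc(-c2ccc(/C=C3\S/C(=N\c4ccc(Cl)cc4)N(c4ccccn4)C3=O)o2)c1` is not yet measured. It differs from compound 3 by chloro in place of fluoro on an aromatic carbon, the same change as that from compound 2 to compound 1, made at the same kind of place on the same kind of ring. On that basis the step of a number no higher from compound 3 to compound 4 (the limit leaves the size open) is expected to be small or unreadable, resting on compound 3 at > 200000 nM and on the unreadable step that the two limits leave unreadable from compound 2 to compound 1. Compound 4 is therefore estimated at 200000 nM, with a range of 100000 nM to 400000 nM, and most likely only a limit will be reported.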

Compound 4, half-maximal cytotoxic concentration: > 200000 nM
Compound 4 ended at the assay's limit (the forecaster's own chance of this, stated with the estimate: 85%); the middle value sits exactly at the limit.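

No new step can be read from compound 3 to compound 4, as both compounds sit at the same limit, which is a limit and not a number: the limit of > 200000 nM in this assay, at which 4 of the 4 values shown sit.

The compounds shown leave open whether chloro in place of fluoro makes any difference in this assay, either between compound 2 and compound 1 or between compound 3 and compound 4.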